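Cytotoxicity Limits Hold Across an Aryl Replacement

This account rests on a few compounds, and the source may have more. Where it says the series, first, only, none or still open, it means among the compounds named here.

Compound 1 `CC(C)N(Cc1cccc(OCCCCCC(=O)O)c1)C(=O)c1ccc(-c2c[nH]c3ccccc23)cc1`: > 26000 nM
Compound 2 `CCOC(=O)CCCCCOc1cccc(CN(C(=O)c2ccc(-c3ccc4ccccc4c3)cc2)C(C)C)c1`: > 26000 nM

Compound 1 was tested in an ADME assay on HEK293 cells (Homo sapiens) for cytotoxicity, read by CellTiter-Glo and resazurin assay, with a stated time of 72 h; a lower number here means that less compound is needed, a higher number that more compound is needed for the effect. In this assay compound 1 gives > 26000 nM, which is a limit of the assay and not a number. In this assay compound 2 gives > 26000 nM, likewise a limit rather than a measured number. Among the compounds with values here, compound 2 therefore stands at the limit of > 26000 nM in this assay, at which 2 of the 2 values shown sit, and the only other value shown keeps it company there, so no order between the two compounds can be read from these figures. Within the data shown here, no step between measured compounds is available.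

Compound 3 `CCOC(=O)CCCCCOc1cccc(CN(C(=O)c2ccc(-c3cccc(OC(F)(F)F)c3)cc2)C(C)C)c1` differs from compound 2 in one place: 3-(trifluoromethoxy)phenyl in place of naphthalen-2-yl on an aromatic carbon. With both measured compounds sitting at the limit of > 26000 nM in this assay, at which 2 of the 2 values shown sit, the step in this assay is expected to show no difference beyond the usual scatter, in either direction. Compound 3 is expected in this assay to give 30000 nM, with a range from 13000 nM to 70000 nM, most likely reported again as a limit. The step that the limit leaves unreadable from compound 2 to compound 3 that this estimate means is expected to stay within the scatter.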

Compound 3, half-maximal effective concentration: > 26000 nM
Compound 3 gave a limit, no number; the forecaster's own chance of this, stated with the estimate: 80%; the middle value does not contradict the limit.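

No step can be read between compound 2 and compound 3 in this assay, as neither gives a number and all the values shown sit together: the limit of > 26000 nM in this assay, at which 3 of the 3 values shown sit.
The compounds shown leave open at what concentration, if any, compound 1, compound 2 or compound 3 would reach the half-maximal effect.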